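Series notes: amide nitrogen substituent, hydroxyethyl to sec-butyl

The compounds below may be only part of what the source reports. "The series", "measured", "known", "first", "only" and "open" are said of these compounds alone.

The set comprises compound 1 `Cc1ccc(OCC(=O)N(CCO)Cc2cccs2)cc1`, compound 2 `CCN(Cc1cccs1)C(=O)COc1ccc(Cl)cc1` and compound 3 `CCN1C(=O)C(Oc2ccc(C)cc2)C1c1cccs1`, with compound 4 `CCC(C)N(Cc1cccs1)C(=O)COc1ccc(C)cc1` still to be measured. In an assay on HEK293 cells for agonist activity at transient receptor potential cation channel subfamily M member 8 (Homo sapiens), read by fluorescence and calcium flux, with a stated time of 15 min (on this read-out higher numbers stand for an effect only at larger amounts of compound and lower numbers for an effect already at smaller amounts), compound 1 gives 900 nM, the highest of the two numbers in hand; compound 2 gives 39 nM, a gap beyond the scatter. Compound 3 is reported only as "active" (no number reported), without a number.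

Compound 4 differs from compound 1 in one place: sec-butyl in place of 2-hydroxyethyl on an amide-type nitrogen. Within the data shown here, no step between measured compounds covers this change. Given that compound 2, which likewise carries no hydrogen-bond donor at that position, gives 39 nM, a move toward a lower number is expected, and the expected step of a 7.5-fold lower number from compound 1 to compound 4 (0.88 log units; beyond the scatter) is beyond the scatter. Compound 4 is accordingly estimated at 120 nM, within a range of 25 nM to 600 nM.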

Compound 4, half-maximal effective concentration: 2000 nM
Compound 4: middle estimate off by 17-fold (1.22 log units), on the low side, and the stated range ends below it.
By their numbers in this assay, from the lowest: compound 2; then compound 1; then compound 4.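

The step to sec-butyl in place of 2-hydroxyethyl on an amide-type nitrogen is a 2.2-fold higher number from compound 1 to compound 4 (0.35 log units; beyond the scatter), so at this position, removing the hydrogen-bond donor and acceptor of 2-hydroxyethyl does not on its own bring a lower number. Among these compounds, this is the first single-place change read at this nitrogen, and it is modest in size. Nothing available explains its direction.

Compound 2 differs from compound 4 in more than one place, so the contribution of its ethyl group stays unseparated. From the compounds shown here alone, how 2-methoxyethyl or 2-aminoethyl would read on the core of compound 1 remains open.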